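The compounds below may be only part of what the source reports. "The series", "measured", "known", "first", "only" and "open" are said of these compounds alone.

Compound 1, `COc1ccc(OC)c(C(=O)/C=C/c2ccc(C(=O)O)cc2)c1`, in a functional assay on PC-3 cells (Homo sapiens) for cytotoxicity, read by MTT assay, with a stated time of 72 h (on this read-out higher numbers stand for weaker inhibition and lower numbers for stronger inhibition), gives 7240 nM.
Compound 2, `COc1ccc(OC)c(C(=O)/C=C/c2ccc(C(=O)OCC=C(C)C)cc2)c1`, in this assay gives > 50000 nM, which is a limit of the assay rather than a number.

Within the data shown here, compound 1 therefore holds the only firm number in this assay; the other value is a limit. Compound 3, `COc1ccc(OC)c(C(=O)/C=C/c2ccc(C(=O)NC3CCCCC3)cc2)c1`, differs from compound 1 in one place: cyclohexylamino in place of hydroxy on a carbonyl carbon. Among the measured compounds shown here, no measured pair shows this exact change. The nearest measured step is an at least 6.9-fold higher number from compound 1 to compound 2 (0.83 log units; beyond the scatter), where the acid hydrogen is likewise replaced on the oxygen next to the carbonyl, and that step runs into (the limit of > 50000 nM in this assay, at which 1 of the 2 values shown sits). Both changes remove the free acid and add carbon, so a higher number in this assay is expected for compound 3, though the amide keeps a hydrogen-bond donor and the size of the shift is uncertain. Compound 3 is estimated at 18000 nM, with a range of 4000 nM to 60000 nM, the expected step being a 2.5-fold higher number from compound 1 to compound 3 (0.40 log units; beyond the scatter).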

Compound 3, half-maximal inhibitory concentration: 6300 nM
Compound 3: middle estimate off by 2.9-fold (0.46 log units), on the high side; the measured number falls inside the stated range.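

The free acid turns out not to be needed at this carbonyl carbon in this assay: exchanging carboxy for cyclohexylcarbamoyl gives a 1.1-fold lower number from compound 1 to compound 3 (0.06 log units; within the scatter). Losing the hydroxy group therefore cannot by itself account for the result of compound 2, since the two compounds without the acid stand far apart, with an at least 7.9-fold lower number from compound 2 to compound 3 (0.89 log units; beyond the scatter). The entry for compound 2 is a limit of the assay, not a number: the limit of > 50000 nM in this assay, at which 1 of the 3 values shown sits.

Compound 2 and compound 3 differ in both the atom bound to the carbonyl carbon and the group beyond it, so the shown compounds cannot separate these two features. A cyclohexyloxy ester would pair the same ring with the ester oxygen, while methylamino or a longer open chain such as butylamino would test whether the cyclohexyl ring matters.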